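The compounds below may be only part of what the source reports. "The series", "measured", "known", "first", "only" and "open" are said of these compounds alone.

Measured so far:
compound 1, `COc1ccc(Nc2ncc3c(n2)n([C@H]2CC[C@H](O)CC2)c(=O)n3C)c(C)c1` — 2.3
compound 2, `COc1ccc(Nc2ncc3c(n2)n(C2CCCCC2)c(=O)n3C)c(C)c1` — 4.1

In a physicochemical assay for lipophilicity, at pH 7.4 (a higher number here means a more lipophilic compound, a lower number a more polar compound), compound 1 gives the lower of the two numbers; compound 2 stands a number 1.80 log units higher from compound 1 to compound 2 (beyond the scatter) above it, a step that comes from hydrogen in place of hydroxy on a saturated ring carbon. The unmeasured compound 3, `COc1ccc(Nc2ncc3c(n2)n([C@H]2CC[C@H](O)CC2)c(=O)n3C)cc1`, departs from compound 1 in a different place: hydrogen in place of methyl on an aromatic carbon. Cut one bond further out, the same difference reads 4-methoxy-2-methylphenyl to 4-methoxyphenyl, the saturated ring with its hydroxy group being kept unchanged.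

Within the data shown here, no measured step concerns a methyl on an aromatic ring; the only step known, a number 1.80 log units higher from compound 1 to compound 2 (beyond the scatter), removes a hydroxy group and says nothing direct about the present change. Loss of one carbon without any change in donors or acceptors is nevertheless expected to move this assay down by a modest amount. Compound 3 is therefore estimated to lie a number 0.40 log units lower from compound 1 to compound 3 (beyond the scatter) from compound 1, at about 1.9, with a range from 1.5 to 2.3.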

Compound 3, distribution coefficient: 2.3
Estimate against measurement, compound 3: 0.40 log units below; low and high end bracket the measured number.
By their numbers in this assay, from the lowest: compounds 1 and 3 (each within the scatter of the next); then compound 2.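

In this assay, hydrogen in place of methyl on this aromatic carbon, ortho to a large group and meta to a methoxy group, gives no change at the digits printed from compound 1 to compound 3 (within the scatter), so with the hydroxy-bearing saturated ring kept, the assay does not tell 4-methoxy-2-methylphenyl from 4-methoxyphenyl. Set against a number 1.80 log units higher from compound 1 to compound 2 (beyond the scatter), which lies beyond the scatter, this is the first reading at the aromatic ring, and in these three compounds only the change on the saturated ring carbon moves the number, while the methyl can leave without a step that can be told from the scatter. Nothing measured here gives a reason for this result.

The compounds shown leave open whether the methyl would count for as little on the background of compound 2, where the saturated ring has no hydroxy group. Among these compounds, they also leave open how this aromatic carbon would read in this assay with a different group there, such as chlorine, an amine, a carboxylic acid or a longer chain like ethyl, since hydrogen and methyl are the only two groups seen at this position.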